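The compounds below may be only part of what the source reports. "The series", "measured", "known", "first", "only" and "open" are said of these compounds alone.

Measured so far:
compound 1, `C#CCN1CCC(OC(=O)Nc2ccccc2)CC1` — an assay on BTI-TN-5B1-4 cells for inhibition of Amine oxidase [flavin-containing] B (Homo sapiens), read by fluorescence and Amplex Red, using microsomes, with a stated time of 15 min; a lower number here means a stronger inhibitor, a higher number a weaker inhibitor: > 100000 nM, a limit of the assay
compound 2, `C#CCN1CCCC(OC(=O)Nc2ccccc2)C1` — this assay: > 100000 nM, also a limit of the assay

Compound 1 stands at the limit of > 100000 nM in this assay, at which 2 of the 2 values shown sit, so only a limit and no number is known for it. Going by the values given here, no step between measured compounds can be drawn from these two limits. Compound 3, `O=C(Nc1ccccc1)OC1CCN(Cc2ccccc2)CC1`, differs from compound 1 by phenyl in place of ethynyl on a saturated chain carbon bound to an amine nitrogen in a ring, which read one bond further out is propargyl to benzyl. With both measured values at the limit, no direction is indicated beyond the scatter. Compound 3 is therefore expected near the limit in this assay, estimated at 70000 nM (range 15000 nM to 300000 nM). The expected step is an at least 1.4-fold lower number from compound 1 to compound 3 (0.15 log units; that floor lies within the scatter).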

Compound 3, half-maximal inhibitory concentration: > 100000 nM
Compound 3: no number, only a limit (the forecaster's own chance of this, stated with the estimate: 60%); middle value at least 1.4-fold (0.15 log units) from the limit.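

Going by these compounds alone, compound 3, like compound 1, gives only a limit of the assay, so no step between the two can be read: the limit of > 100000 nM in this assay, at which 3 of the 3 values shown sit.
In this assay the compounds shown leave open how strongly any of them inhibits and whether benzyl differs from propargyl at all.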